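The compounds below may be only part of what the source reports. "The series", "measured", "known", "first", "only" and "open" are said of these compounds alone.

Compound 1 `O=C(c1ccc(Cl)nc1)N1N=C(c2ccc(Cl)cc2)CC1c1ccc(OCc2ccccc2)cc1` gives 13200 nM in a functional assay on WM 266-4 cells (Homo sapiens) for antiproliferative activity, read by MTT assay, with a stated time of 24 h; a lower number here means a stronger inhibitor of growth, a higher number a weaker inhibitor of growth. Compound 2 `Cc1ccc(C(=O)N2N=C(c3ccc(Cl)cc3)CC2c2ccc(OCc3ccccc3)cc2)c(Cl)n1` carries 2-chloro-6-methylpyridin-3-yl in place of 6-chloropyridin-3-yl on a carbonyl carbon and in this assay compound 2 gives 11400 nM; the step is a 1.2-fold lower number from compound 1 to compound 2 (0.06 log units; within the scatter). Compound 3 `O=C(c1ccc(Cl)nc1)N1N=C(c2ccc(Cl)cc2)CC1c1ccc(Br)cc1` gives 9870 nM in this assay, and the step is a 1.3-fold lower number from compound 1 to compound 3 (0.13 log units; within the scatter). The three numbers all lie within the scatter of one another, so no ordering among them is claimed. Compound 4 `Cc1ccc(C(=O)N2N=C(c3ccc(Cl)cc3)CC2c2ccc(Br)cc2)c(Cl)n1` is not yet measured. Its change from compound 3 is 2-chloro-6-methylpyridin-3-yl in place of 6-chloropyridin-3-yl on a carbonyl carbon, the same change as from compound 1 to compound 2, with the place described in the same words. The two cores differ by bromo in place of benzyloxy on an aromatic carbon. For compound 4 a step of a 1.2-fold lower number from compound 3 to compound 4 (0.06 log units; within the scatter) is expected, resting on the earlier step of a 1.2-fold lower number from compound 1 to compound 2 (0.06 log units; within the scatter), which stayed within the scatter. Compound 4 is thus estimated at 8500 nM, with a range from 4500 nM to 16000 nM.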

Compound 4, concentration for 50% growth inhibition: 10800 nM
For compound 4 the middle estimate is 1.3-fold (0.10 log units) below the measured one; low and high end bracket the measured number.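

In this assay, 2-chloro-6-methylpyridin-3-yl in place of 6-chloropyridin-3-yl on the carbonyl carbon gives a 1.1-fold higher number from compound 3 to compound 4 (0.04 log units; within the scatter), and the two steps for this change agree: the same change on two cores in this assay, a 1.2-fold lower number (0.06 log units; within the scatter) from compound 1 to compound 2 and a 1.1-fold higher number (0.04 log units; within the scatter) from compound 3 to compound 4, 1.3-fold (0.10 log units) apart, within the scatter of two such steps. Bromo in place of benzyloxy gives a 1.1-fold lower number from compound 2 to compound 4 (0.02 log units; within the scatter), and its two steps agree as well: the same change on two cores in this assay, a 1.3-fold lower number (0.13 log units; within the scatter) from compound 1 to compound 3 and a 1.1-fold lower number (0.02 log units; within the scatter) from compound 2 to compound 4, 1.3-fold (0.10 log units) apart, within the scatter of two such steps. Neither change takes the number beyond the scatter on either core, which shows only that both stay within it on these cores, not that a measurable effect carries from one core to another.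

Going by these compounds, it remains open whether an amine or a carboxylic acid in place of bromo would give a step beyond the scatter. The same question stands for a longer chain in place of benzyloxy.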